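The source may hold more compounds than are shown below. What is called first, only, known or untested is meant among the compounds shown, and "the series" means these compounds.

Compound 1 `CC(O)(CSc1cccc(S(F)(F)(F)(F)F)c1)C(=O)Nc1ccc([N+](=O)[O-])c(C(F)(F)F)c1`: 8800 nM
Compound 2 `CC(O)(CS(=O)(=O)c1ccc(S(F)(F)(F)(F)F)cc1)C(=O)Nc1cccc(S(F)(F)(F)(F)F)c1`: 12300 nM
Compound 3 `CC(O)(CS(=O)(=O)c1ccc(F)cc1)C(=O)Nc1cccc(S(F)(F)(F)(F)F)c1`: 38900 nM

All three compounds were tested in a functional assay on CWR22R cells (Homo sapiens) for antiproliferative activity, read by propidium iodide staining, with a stated time of 96 h; on this read-out higher numbers stand for weaker inhibition and lower numbers for stronger inhibition. Compound 3, at 38900 nM, has the highest number of the three, which makes it the weakest inhibitor so far, and its gaps to both others lie beyond the scatter.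

The next compound, compound 4 `CC(O)(CS(=O)(=O)c1ccccc1C(F)(F)F)C(=O)Nc1cccc(S(F)(F)(F)(F)F)c1`, keeps the rest of compound 3 but changes the aromatic group on the sulfonyl sulfur: 2-(trifluoromethyl)phenyl in place of 4-fluorophenyl on a sulfonyl sulfur. In words, 2-(trifluoromethyl)phenyl stands in place of 4-fluorophenyl on a sulfonyl sulfur.

Among the measured compounds shown here, only one measured step touches this group. Going a 3.2-fold higher number from compound 2 to compound 3 (0.50 log units; beyond the scatter), fluorine replaces pentafluorosulfanyl on the same ring. Read backwards, that step suggests that moving away from the simple fluorine compound may lower the number by a modest amount. It is a weak guide, however. For the measured compounds named here, no measured compound carries 2-(trifluoromethyl)phenyl, and compound 1 differs from compound 3 in too many places to help. A small shift towards stronger inhibition in this assay is therefore the best expectation, and no real change would be no surprise.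

The expected change is a 1.8-fold lower number from compound 3 to compound 4 (0.25 log units; within the scatter). Compound 4 is estimated at 22000 nM, with an expected range from 8000 nM to 60000 nM.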

Compound 4, half-maximal inhibitory concentration: 27700 nM
Estimate against measurement, compound 4: 1.3-fold (0.10 log units) below; measured number inside the range.
By their numbers in this assay, from the lowest: compounds 1 and 2 (each within the scatter of the next); then compounds 4 and 3 (each within the scatter of the next).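

In this assay, putting 2-(trifluoromethyl)phenyl in place of 4-fluorophenyl on the sulfonyl sulfur gives a 1.4-fold lower number from compound 3 to compound 4 (0.15 log units; within the scatter), so the larger group and the different place of the substituent on the ring leave the two numbers indistinguishable. Among the compounds shown here, this adds something that the only earlier step on this group could not show: that step, a 3.2-fold higher number from compound 2 to compound 3 (0.50 log units; beyond the scatter), lies beyond the scatter, whereas this one shows that not every change to the aromatic group on the sulfonyl sulfur separates a compound from compound 3. Among the compounds shown, nothing explains why one change to this group gives a step beyond the scatter and the other does not.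

As far as these compounds go, it remains open whether a plain phenyl ring, or a ring carrying an amine or a carboxylic acid, on the sulfonyl sulfur would give a number clearly apart from that of compound 3. From the compounds shown here alone, it is also open whether the same swap would give a similarly small step on the core of compound 1.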